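A few compounds are considered here, and "the series" means these few. Any claim that something is new, unique, unknown or untested is made for them only; others in the source may bear on it.

Measured compounds in a functional assay on HEK293 cells (Homo sapiens) for cytotoxicity; on this read-out lower numbers stand for higher toxicity in this test and higher numbers for lower toxicity in this test:
Compound 1 `COc1ccc([C@H]2CC(=O)N(c3cccc(S(C)(=O)=O)c3)C2)cc1OC1CCCC1` gives > 10000 nM, which is a limit of the assay and not a number.
Compound 2 `COc1ccc([C@H]2CC(=O)N(c3cccc(NCc4ccoc4)c3)C2)cc1OC1CCCC1` gives > 10000 nM, also a limit of the assay.
Compound 3 `COc1ccc(S(=O)(=O)Nc2cccc(N3C[C@@H](c4ccc(OC)c(OC5CCCC5)c4)CC3=O)c2)cc1` gives > 10000 nM, again a limit of the assay.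

Compound 3 therefore stands at the limit of this assay, and only a limit is known for it; the same holds for the two other measured compounds, as the limit of > 10000 nM in this assay, at which 3 of the 3 values shown sit, shows. The steps a step that the two limits leave unreadable from compound 1 to compound 2, a step that the two limits leave unreadable from compound 1 to compound 3 and a step that the two limits leave unreadable from compound 2 to compound 3 have no readable size, since both ends of each sit at the limit.

Compound 4 `COc1ccc([C@H]2CC(=O)N(c3cccc(NS(=O)(=O)c4cccc(Cl)c4C)c3)C2)cc1OC1CCCC1` differs from compound 3 by 3-chloro-2-methylphenyl in place of 4-methoxyphenyl on a sulfonyl sulfur. For the measured compounds named here, none of the measured steps touches this part of the molecule, so no step bears directly on the change. Every exchange among the three measured compounds has left the value at the limit, and the expectation is that compound 4 also stays beyond it. The step is expected to be a step that the limit leaves unreadable from compound 3 to compound 4. Compound 4 is estimated at 15000 nM, within a range from 5000 nM to 50000 nM.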

Compound 4, half-maximal cytotoxic concentration: > 10000 nM
Compound 4: a limit, no number (the forecaster's own chance of this, stated with the estimate: 80%); the middle value lies beyond the limit too.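

For the compounds shown here, compound 4 gives > 10000 nM in this assay, which is a limit of the assay and not a number, so no step from compound 1, compound 2 or compound 3 to compound 4 can be read. The compounds shown leave open how these four compounds differ in this test, and whether any change would give a readable value.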